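Dropping a Trifluoromethyl Group: Expected Effect on Growth Inhibition

A few compounds are considered here, and "the series" means these few. Any claim that something is new, unique, unknown or untested is made for them only; others in the source may bear on it.

Measured compounds:
compound 1, `COc1cc(-c2nn(-c3cccc(NC(=O)c4cccc(C(F)(F)F)c4)c3)cc2-c2ccncc2)ccc1Cl`, 1200 nM
compound 2, `O=C(Nc1cccc(-n2cc(-c3ccncc3)c(-c3ccc(Cl)c(O)c3)n2)c1)Nc1cc(C(F)(F)F)cc(C(F)(F)F)c1`, 400 nM

Of these two, compound 1 has the higher number in a functional assay on OVCAR-3 cells (Homo sapiens) for inhibition, read by sulforhodamine B assay, with a stated time of 48 h (a lower number here means a stronger inhibitor, a higher number a weaker inhibitor), so it is the weaker inhibitor, and its gap to compound 2 lies beyond the usual scatter. Compound 2 differs from compound 1 in several places at once, so no single change can be read from that pair.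

Compound 3, `COc1cc(-c2nn(-c3cccc(NC(=O)c4ccccc4)c3)cc2-c2ccncc2)ccc1Cl`, differs from compound 1 in one place: hydrogen in place of trifluoromethyl on an aromatic carbon. Among the measured compounds shown here, no measured pair shows this change, so the expectation rests on the structures alone. A modest rise in the number is expected, a step of a 2.1-fold higher number from compound 1 to compound 3 (0.32 log units; beyond the scatter) that may only just exceed the scatter. Compound 3 is expected to give 2500 nM, within 1000 nM to 6000 nM.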

Compound 3, half-maximal inhibitory concentration: 330 nM
Beside the measured number, compound 3's estimate is 7.6-fold (0.88 log units) above it; measured number outside the range, below it.
By their numbers in this assay, from the lowest: compounds 3 and 2 (each within the scatter of the next); then compound 1.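

In this assay the change from 3-(trifluoromethyl)phenyl to phenyl gives a 3.6-fold lower number from compound 1 to compound 3 (0.56 log units; beyond the scatter) so the trifluoromethyl is not needed for activity at this position. In this pair, the compound with plain hydrogen on that aromatic carbon is the stronger inhibitor. Nothing available explains why removing the group has this effect. The compounds shown leave open whether a fluorine, a methyl or an amine on this carbon would give a number closer to that of compound 3 or of compound 1.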